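A few compounds are considered here, and "the series" means these few. Any claim that something is new, unique, unknown or untested is made for them only; others in the source may bear on it.

Going by the values given here, in a functional assay on KYSE-450 cells (Homo sapiens) for inhibition, read by MTT assay, with a stated time of 48 h (on this read-out higher numbers stand for weaker inhibition and lower numbers for stronger inhibition), compound 3 (`CCC/C=C/C(=O)N(Cc1ccc(OC)c(O)c1)c1cc(OC)c(OC)c(OC)c1`) gives 57 nM, the lowest number of the three so far. Compound 1 (`COc1ccc(CN(C(=O)C(C)Br)c2cc(OC)c(OC)c(OC)c2)cc1O`) gives 160 nM and compound 2 (`C/C=C/C=C/C(=O)N(Cc1ccc(OC)c(O)c1)c1cc(OC)c(OC)c(OC)c1`) gives 180 nM. Compound 4 (`CC/C=C/C(=O)N(Cc1ccc(OC)c(O)c1)c1cc(OC)c(OC)c(OC)c1`) has hydrogen in place of methyl on a saturated chain carbon, two bonds along the chain from a double-bonded chain carbon. The nearest evidence is a 3.2-fold lower number from compound 2 to compound 3 (0.50 log units; beyond the scatter), on the same chain, alongside a 2.8-fold lower number from compound 1 to compound 3 (0.45 log units; beyond the scatter) and a 1.1-fold higher number from compound 1 to compound 2 (0.05 log units; within the scatter), the last within the scatter. Among the compounds with values here, no measured pair shortens this chain, so direction is uncertain. A modest rise in the number is expected, of the size seen in a 3.2-fold lower number from compound 2 to compound 3 (0.50 log units; beyond the scatter) at most. The expected change is a 1.7-fold higher number from compound 3 to compound 4 (0.22 log units; within the scatter). The estimate for compound 4 is 95 nM, with an expected range of 40 nM to 220 nM.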

Compound 4, half-maximal inhibitory concentration: 72 nM
Beside the measured number, compound 4's estimate is 1.3-fold (0.12 log units) above it; the range from low to high includes it.
By their numbers in this assay, from the lowest: compounds 3 and 4 (each within the scatter of the next); then compounds 1 and 2 (each within the scatter of the next).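

In this assay the change from propyl to ethyl stays within the scatter (a 1.3-fold higher number from compound 3 to compound 4 (0.10 log units; within the scatter)), so the methyl lost at this place is not needed to keep the number low. The advantage over the other two acyl groups survives the shortening, with a 2.5-fold lower number from compound 2 to compound 4 (0.40 log units; beyond the scatter) and a 2.2-fold lower number from compound 1 to compound 4 (0.35 log units; beyond the scatter) both beyond the scatter. No measurement here gives a cause for these steps.

Still open, going by these compounds, is how far this tolerance extends: whether a prop-1-en-1-yl or a longer chain such as hept-1-en-1-yl holds the number. Also open, on these data alone, is whether an amine or a carboxylic acid at the chain end does the same.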